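Removing a methoxy group from an inactive compound

The compounds below may be only part of what the source reports. "The series", "measured", "known", "first", "only" and "open" are said of these compounds alone.

Compound 1 `CCCCCC1=CC(=N)C(C)(C)O1` and compound 2 `CCC1(C)OC(/C(C)=C/COc2ccc3ccc(=O)oc3c2)=CC1=N` were tested in a functional assay on FM3A cells (Mus musculus); a lower number here means a stronger inhibitor, a higher number a weaker inhibitor. In this assay compound 1 gives 24.2 ug/mL, and compound 2 gives 14.1 ug/mL. Compound 3 `COc1ccccc1C1=CC(=O)CO1` stands apart: in this assay compound 3 gives > 100 ug/mL, which is a limit of the assay and not a number. That is the value sitting at the limit of > 100 ug/mL in this assay, at which 1 of the 3 values shown sits. Compound 4 `O=C1C=C(c2ccccc2)OC1` is made from compound 3 by one change: hydrogen in place of methoxy on an aromatic carbon. For the measured compounds named here, no measured step of this kind is available, so the expected step that the limit leaves unreadable from compound 3 to compound 4 is none beyond the scatter. Compound 4 is therefore expected to give about 150 ug/mL, with a likely range from 60 ug/mL to 400 ug/mL, and most probably again only a limit.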

Compound 4, concentration for 50% inhibition: 31.4 ug/mL
Estimate against measurement, compound 4: 4.8-fold (0.68 log units) above; the whole stated range lies above it.
By their numbers in this assay, from the lowest: compounds 2, 1 and 4 (each within the scatter of the next, the first and the last beyond it). At a limit, above all of these: compound 3.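

In this assay, hydrogen in place of methoxy on an aromatic carbon gives an at least 3.1-fold lower number from compound 3 to compound 4 (0.50 log units; beyond the scatter). For the compounds shown here, this pair is the first to show that this one place on the ring can move the result beyond the scatter, and that the compound keeps a measurable number without the methoxy group. The value of compound 3 is a limit and not a number, so the full size of the step stays unknown: the limit of > 100 ug/mL in this assay, at which 1 of the 4 values shown sits.

The compounds shown do not say why methoxy and hydrogen differ here. They also leave open whether a fluorine, a hydroxyl or an amine at this place would read like hydrogen or like methoxy.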